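The source may report more compounds than this note shows. Statements on the series, on what has been measured and on what is new or still open speak of the compounds shown alone.

Three compounds have been measured in a functional assay on Hep 3B2 cells (Homo sapiens) for inhibition, read by sulforhodamine B assay, with a stated time of 72 h, tested at 10 uM; on this read-out higher numbers stand for more inhibition at the one concentration tested (going by the name of the read-out) and lower numbers for less inhibition:
compound 1 `C[C@H](Nc1ncnc2[nH]cnc12)c1nn(-c2cccnc2)c2cc(F)ccc12`, 20%
compound 2 `CC(C)[C@H](Nc1ncnc2[nH]cnc12)c1nn(-c2cccnc2)c2cc(F)ccc12`, 4%
compound 3 `C[C@H](Nc1nc(N)nc2[nH]cnc12)c1nn(-c2cccnc2)c2cc(F)ccc12`, 14%

Compound 1 has the highest of the three numbers. Its nearest neighbour is compound 3, and the step of a number 6 percentage points lower from compound 1 to compound 3 (within the scatter) lies within the scatter, so no order can be read between those two. The step of a number 16 percentage points lower from compound 1 to compound 2 (beyond the scatter) is beyond the scatter and modest. Compound 4 `C[C@H](Nc1ncnc2[nH]cnc12)c1nn(-c2cc(F)cc(F)c2)c2cc(F)ccc12` differs from compound 1 by 3,5-difluorophenyl in place of pyridin-3-yl on an aromatic nitrogen. Neither measured step touches this place: one alters the saturated chain carbon, the other an aromatic carbon. Going by the values given here, no measured step therefore bears directly on this change, and the narrow spread of the three numbers gives no ground to expect a large move. A step of a number 2 percentage points lower from compound 1 to compound 4 (within the scatter) is expected, staying within the scatter. The estimate for compound 4 is 18%, between 4% and 36%.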

Compound 4, a percentage reported as inhibition, at one concentration (the size of the read-out at that concentration, not a potency): 14%
Beside the measured number, compound 4's estimate is 4 percentage points above it; measured number inside the range.
By their numbers in this assay, from the lowest: compounds 2, 3, 4 and 1 (each within the scatter of the next, the first and the last beyond it).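

Among these compounds, only this pair differs in the group on the aromatic nitrogen. In this assay, 3,5-difluorophenyl in place of pyridin-3-yl gives a number 6 percentage points lower from compound 1 to compound 4 (within the scatter) and so shows no readable change at this position, even though a carbon-only ring with two fluorines replaces a ring containing nitrogen. Nothing available explains this result.

Still open, on these data alone, is whether a simple methyl or a longer chain on that nitrogen would change the number. The same holds for a phenyl ring carrying an amine or a carboxylic acid.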